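Aryl Variation on a Shared Core and Cytotoxicity

The source may report more compounds than this note shows. Statements on the series, on what has been measured and on what is new or still open speak of the compounds shown alone.

Three compounds have been measured:
compound 1 `C=CCn1c(=O)/c(=C\c2cc(F)ccc2C)[nH]c(=O)/c1=C\c1ccccc1OC`: 3800 nM
compound 2 `C=CCn1c(=O)/c(=C\c2ccccc2F)[nH]c(=O)/c1=C\c1ccccc1OC`: 20000 nM
compound 3 `C=CCn1c(=O)/c(=C\c2cccc(Cl)c2)[nH]c(=O)/c1=C\c1ccccc1OC`: 4900 nM

All three share one core and differ only in the aryl group on a double-bonded chain carbon bound to an aromatic carbon. In a functional assay on MOLT-4 cells (Homo sapiens) for cytotoxicity, read by CCK-8 assay, with a stated time of 72 h (a lower number here means a stronger inhibitor, a higher number a weaker inhibitor), compound 3 stands second highest of the three numbers: a 1.3-fold higher number from compound 1 to compound 3 (0.11 log units; within the scatter), whereas a 4.1-fold lower number from compound 2 to compound 3 (0.61 log units; beyond the scatter). The remaining step is a 5.3-fold higher number from compound 1 to compound 2 (0.72 log units; beyond the scatter).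

Compound 4 `C=CCn1c(=O)/c(=C\c2cc(Br)ccc2F)[nH]c(=O)/c1=C\c1ccccc1OC` has not yet been tested. Its change from compound 3 is 5-bromo-2-fluorophenyl in place of 3-chlorophenyl on a double-bonded chain carbon bound to an aromatic carbon. The incoming group carries a fluorine as in compound 2 and a second substituent as in compound 1. The step of a 4.1-fold lower number from compound 2 to compound 3 (0.61 log units; beyond the scatter) shows that the 2-fluorophenyl compound sits well above the 3-chlorophenyl compound, while a 1.3-fold higher number from compound 1 to compound 3 (0.11 log units; within the scatter) shows that the 5-fluoro-2-methylphenyl compound sits level with it. Compound 4 resembles compound 1 in having two substituents on the ring, so the expectation is a number close to compound 3, with a wide range to cover the case that it behaves more like compound 2. The expected step is a 1.0-fold higher number from compound 3 to compound 4 (0.01 log units; within the scatter). The estimate for compound 4 in this assay is 5000 nM, between 2000 nM and 15000 nM.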

Compound 4, half-maximal inhibitory concentration: 12900 nM
For compound 4 the middle estimate is 2.6-fold (0.41 log units) below the measured one; the measured number falls inside the stated range.
By their numbers in this assay, from the lowest: compounds 1 and 3 (each within the scatter of the next); then compounds 4 and 2 (each within the scatter of the next).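

In this assay, bromo in place of hydrogen on the ring of compound 2 gives a 1.6-fold lower number from compound 2 to compound 4 (0.19 log units; within the scatter) and so yields no reading distinct from the 2-fluorophenyl compound. A second ring substituent alone therefore does not bring a compound level with the lower pair: compound 4 has two substituents as compound 1 does, yet the data show a 3.4-fold higher number from compound 1 to compound 4 (0.53 log units; beyond the scatter) and also a 2.6-fold higher number from compound 3 to compound 4 (0.42 log units; beyond the scatter) as steps beyond the scatter. Among these four, the 2-fluorophenyl and 5-bromo-2-fluorophenyl compounds stand together above compounds 1 and 3, while the fluorine carried by compound 1 goes against any reading that a ring fluorine by itself accompanies the higher number.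

Nothing available gives a measured reason for the separation of these two pairs. On these data alone, it remains open whether an amine or a carboxylic acid in place of the bromo on the 2-fluorophenyl ring would also stay level with compound 2, or whether a methyl in place of its fluoro would bring the number toward that of compound 1.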